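Dienone series: cytotoxicity in hepatoma cells

A few compounds are considered here, and "the series" means these few. Any claim that something is new, unique, unknown or untested is made for them only; others in the source may bear on it.

Measured so far:
compound 1, `Cc1ccc(/C=C/C=C2\CCC=CC2=O)cc1`, 8600 nM
compound 2, `COc1ccccc1/C=C/C=C1\CCC=CC1=O`, 5800 nM

In a functional assay on HepG2 cells (Homo sapiens) for cytotoxicity, read by MTT assay, with a stated time of 72 h (a lower number here means a stronger inhibitor, a higher number a weaker inhibitor), compound 1 gives 8600 nM. Compound 2 gives 5800 nM in this assay; the two values lie within the usual scatter of each other, so neither compound stands apart on the numbers shown. Compound 3, `CN(C)c1ccc(/C=C/C=C2\CCC=CC2=O)cc1`, differs from compound 1 by dimethylamino in place of methyl on an aromatic carbon. Within the data shown here, no step between measured compounds covers this change, so the expectation rests only on the two values shown. The step of a 1.4-fold lower number from compound 1 to compound 3 (0.16 log units; within the scatter) is expected to be small, not clearly beyond the scatter in either direction. Compound 3 is estimated at 6000 nM, with a range of 2500 nM to 15000 nM.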

Compound 3, half-maximal inhibitory concentration: 1100 nM
The estimate for compound 3 lay 5.5-fold (0.74 log units) above the measured number; the measured number lies below the stated range.
By their numbers in this assay, from the lowest: compound 3; then compounds 2 and 1 (each within the scatter of the next).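

At this position, on an aromatic carbon para to a large group, dimethylamino in place of methyl gives a 7.8-fold lower number from compound 1 to compound 3 (0.89 log units; beyond the scatter) in this assay and so clears the scatter, which the two earlier values did not do. This position therefore responds to a change of group, at least for this one change. Nothing shown bears on why the step occurs.

Still open, as far as these compounds go, is whether an unsubstituted amine, a diethylamino group or a morpholine ring at this position gives a step of similar size. Also open, from the compounds shown here alone, is whether dimethylamino placed elsewhere on the ring does the same.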